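The compounds below may be only part of what the source reports. "The series", "measured", "known", "first", "only" and "open" are said of these compounds alone.

Working notes on the series. Compound 1 `Nc1n/c(=N\CCCCc2ccccc2)nc(N)c2c1ncn2Cc1ccccc1` gives 16700 nM in a functional assay on MDA-MB-231 cells (Homo sapiens) for antiproliferative activity, read by WST assay, with a stated time of 72 h; on this read-out lower numbers stand for stronger inhibition and higher numbers for weaker inhibition. Compound 2 `CCCCCCCCCCCCCCCCCC/N=c1\nc(N)c2ncn(Cc3ccccc3)c2c(N)n1` gives 5400 nM in this assay. Compound 3 `CCCCCCCCCC/N=c1\nc(N)c2ncn(Cc3ccccc3)c2c(N)n1` gives 2050 nM in this assay, the lowest of the three numbers; compound 2 is nearest and compound 1 furthest. The step of an 8.1-fold lower number from compound 1 to compound 3 (0.91 log units; beyond the scatter) is the larger of the two measured steps, the step of a 2.6-fold lower number from compound 2 to compound 3 (0.42 log units; beyond the scatter) the smaller, and both lie beyond the scatter.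

Compound 4 `CCCCCCCC/N=c1\nc(N)c2ncn(Cc3ccccc3)c2c(N)n1` differs from compound 3 by hydrogen in place of ethyl on a saturated chain carbon, eight bonds along the chain from a double-bonded nitrogen. Both measured steps bear on it, since each also alters the chain on the double-bonded nitrogen, but neither repeats this change: one removes a far longer piece of chain, the other swaps a ring for a chain. Shortening from compound 2 to compound 3 lowered the number, while the shorter chain of compound 1 goes against any simple reading that shorter is better, so compound 3 may sit near a best length. For compound 4 a step of a 1.3-fold higher number from compound 3 to compound 4 (0.10 log units; within the scatter) within the scatter is expected. Compound 4 is expected to give 2600 nM in this assay, with a range of 1100 nM to 6500 nM.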

Compound 4, half-maximal inhibitory concentration: 4750 nM
Estimate against measurement, compound 4: 1.8-fold (0.26 log units) below; measured number inside the range.
By their numbers in this assay, from the lowest: compound 3; then compounds 4 and 2 (each within the scatter of the next); then compound 1.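

Removing ethyl at this place matters in this assay: the step of a 2.3-fold higher number from compound 3 to compound 4 (0.36 log units; beyond the scatter) shows that even this small shortening of the chain, eight bonds along from the double-bonded nitrogen, moves the number beyond the scatter. The step of a 1.1-fold lower number from compound 2 to compound 4 (0.06 log units; within the scatter) leaves the octyl and the far longer chain of compound 2 with no separation, so among these three straight chains the lowest number belongs to compound 3 alone, and shortening does not lower the number throughout. The step of a 3.5-fold lower number from compound 1 to compound 4 (0.55 log units; beyond the scatter) shows that butyl in place of phenyl still gives a lower number with the shorter octyl chain, although less of one than hexyl gives in compound 3.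

Nothing at hand gives a cause for these steps. Going by these compounds, whether a dodecyl chain would go lower than compound 3, and whether an amine at the chain end would keep its number, stays open.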